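Alkyl branching next to the sulfonamide nitrogen of compound 1

The source may report more compounds than this note shows. Statements on the series, on what has been measured and on what is new or still open speak of the compounds shown alone.

Compound 1 `COc1ccc(S(=O)(=O)NCCCN2CCN(c3cccc(C(F)(F)F)c3)CC2)cc1`: in an assay on HeLa cells for displacement of a labelled ligand from 5-hydroxytryptamine receptor 6 (Homo sapiens) (a lower number here means a stronger inhibitor, a higher number a weaker inhibitor), compound 1 gives 2840 nM.
Compound 2 `COc1ccc(S(=O)(=O)NCCCN2CCN(c3ccccc3OC)CC2)cc1`: in this assay compound 2 gives > 10000 nM, which is a limit of the assay.

Among the measured compounds shown here, compound 1 stands as the only true number here; the other value is a limit. For the measured compounds named here, the one measured step, an at least 3.5-fold higher number from compound 1 to compound 2 (0.54 log units; beyond the scatter), is an aryl exchange, and its size is set by the limit of > 10000 nM in this assay, at which 1 of the 2 values shown sits. Compound 3 `COc1ccc(S(=O)(=O)NC(C)CCN2CCN(c3cccc(C(F)(F)F)c3)CC2)cc1` differs from compound 1 by methyl in place of hydrogen on a saturated chain carbon bound to a saturated chain carbon and a sulfonamide nitrogen, a change at a different place on the chain, so that step carries no direct bearing. No shift beyond the scatter is therefore expected: compound 3 is estimated at 3000 nM (range 1000 nM to 10000 nM), a step of a 1.1-fold higher number from compound 1 to compound 3 (0.02 log units; within the scatter).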

Compound 3, half-maximal inhibitory concentration: 6930 nM
Beside the measured number, compound 3's estimate is 2.3-fold (0.36 log units) below it, and the stated range covers the measured number.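

In this assay, methyl in place of hydrogen on this saturated chain carbon brings a 2.4-fold higher number from compound 1 to compound 3 (0.39 log units; beyond the scatter), the first step shown on the chain rather than on the aryl group. Both ends of this step are true numbers, so the chain position itself is seen to respond, if only modestly, to a single added methyl. Nothing shown accounts for the shift.

As far as these compounds go, whether an ethyl or a cyclopropyl group at this carbon would move the number further remains open. So does whether methyl here would act alike with 2-methoxyphenyl on the ring amine nitrogen.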